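Swapping the amide aryl group in a weak K562 series

A few compounds are considered here, and "the series" means these few. Any claim that something is new, unique, unknown or untested is made for them only; others in the source may bear on it.

Measured so far:
- compound 1 `COc1ccc(C(=O)Nc2ccc(Cl)cn2)cc1Nc1nccc(-c2cccnc2)n1`: "not determined" (no result reported)
- compound 2 `COc1ccc(C(=O)Nc2cccc(F)c2)cc1Nc1nccc(-c2cccnc2)n1`: "not determined" (no result reported)
- compound 3 `COc1ccc(C(=O)Nc2cc(Br)cc(C(F)(F)F)c2)cc1Nc1nccc(-c2cccnc2)n1`: 215000 nM

Three compounds share a common core and differ only in the aryl group carried on the amide nitrogen. Among the compounds with values here, in a functional assay on K562 cells (Homo sapiens) for antiproliferative activity, read by MTT assay, with a stated time of 48 h (on this read-out higher numbers stand for weaker inhibition and lower numbers for stronger inhibition), compound 1 gives "not determined" (no result reported), and compound 2 gives "not determined" (no result reported), so compound 3 is the only one with a value. In this assay compound 3 gives 215000 nM, which on this scale is a very weak effect. It is therefore the sole point of reference, and nothing can be said about how the aryl group shifts the read-out within the measured set.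

Compound 4 `COc1ccc(C(=O)Nc2cccc(C(C)=O)c2)cc1Nc1nccc(-c2cccnc2)n1` is the next step. It differs from compound 3 in one place: 3-acetylphenyl in place of 3-bromo-5-(trifluoromethyl)phenyl on an amide-type nitrogen. Without any measured pair to calibrate on, the expected step from compound 3 to compound 4 is small, most likely none beyond the usual scatter, as a 1.2-fold lower number from compound 3 to compound 4 (0.08 log units; within the scatter) expresses. Compound 4 is accordingly estimated at 180000 nM in this assay, within a range of 40000 nM to 700000 nM.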

Compound 4, half-maximal inhibitory concentration: 237000 nM
Compound 4: the middle estimate sits 1.3-fold (0.12 log units) below what was measured; the measured number falls inside the stated range.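

In this assay, within the data shown here, the first measured pair at this amide nitrogen gives a 1.1-fold higher number from compound 3 to compound 4 (0.04 log units; within the scatter), so compound 3 and compound 4 read alike. The aryl group can thus lose its bromine and trifluoromethyl and gain an acetyl group, with its additional hydrogen-bond acceptor, without the number leaving the scatter of repeated measurements. No measurement shown here accounts for this similarity.

On these data alone, compound 1 and compound 2 give no number, so steps involving them cannot be read, and it remains open whether any aryl group at this position can move the read-out beyond the scatter. As far as these compounds go, it is also open whether a phenyl group carrying an amine or a carboxylic acid in place of the acetyl group would read differently from compound 4.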